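The source may report more compounds than this note shows. Statements on the series, on what has been measured and on what is new or still open speak of the compounds shown alone.

Measured so far in a functional assay on SK-BR-3 cells (Homo sapiens) for inhibition, read by CellTiter-Glo, with a stated time of 72 h; on this read-out lower numbers stand for stronger inhibition and higher numbers for weaker inhibition:
compound 1 `CC(C)c1nn(-c2ccc(C(N)=O)c(N[C@H]3CC[C@H](O)CC3)c2)c2nccc(-n3cnc(-c4ccc(Oc5ccccc5)cc4)c3)c12`, 503 nM
compound 2 `CC(C)c1nn(-c2ccc(C(N)=O)cc2)c2nccc(-n3cnc(-c4cnn(C)c4)c3)c12`, 1640 nM
compound 3 `CC(C)c1nn(-c2ccc(C(N)=O)c(N[C@H]3CC[C@H](O)CC3)c2)c2ccnc(-c3cnc4ccccc4c3)c12`, 1720 nM

Compound 1 gives the lowest number of the three; its gaps to compound 2 and to compound 3 both lie beyond the usual scatter, so it is the most potent of the measured set. The numbers for compound 2 and compound 3 sit within the scatter of each other.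

Compound 4 `CC(C)c1nn(-c2ccc(C(N)=O)c(N[C@H]3CC[C@H](O)CC3)c2)c2nccc(-n3cnc(-c4ccccc4)c3)c12` is not yet measured. It differs from compound 1 in one place: hydrogen in place of phenoxy on an aromatic carbon, para to a large group. Among the measured compounds shown here, no measured pair shows this change, so the size of the step is open. A weakening step beyond the scatter is expected, estimated at a 2.6-fold higher number from compound 1 to compound 4 (0.41 log units; beyond the scatter) in this assay. For compound 4 the estimate is 1300 nM, in the range 450 nM to 4000 nM.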

Compound 4, half-maximal inhibitory concentration: 276 nM
The estimate for compound 4 lay 4.7-fold (0.67 log units) above the measured number; the whole stated range lies above it.
By their numbers in this assay, from the lowest: compounds 4 and 1 (each within the scatter of the next); then compounds 2 and 3 (each within the scatter of the next).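

Hydrogen in place of phenoxy on this aromatic carbon, para to a large group, gives a 1.8-fold lower number from compound 1 to compound 4 (0.26 log units; within the scatter) in this assay. The large phenoxy group can therefore be removed from this position without a change beyond the scatter, and compound 1's standing in the series does not depend on it. Nothing measured here accounts for this result.

Going by these compounds, whether methoxy, an amine or a carboxylic acid on this carbon would move the number remains open. So does whether this step would hold on a different core.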